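A few compounds are considered here, and "the series" means these few. Any claim that something is new, unique, unknown or untested is made for them only; others in the source may bear on it.

Measured so far in a functional assay on cells for agonist activity at Free fatty acid receptor 1 (Homo sapiens), read by FLIPR and calcium flux; on this read-out higher numbers stand for an effect only at larger amounts of compound and lower numbers for an effect already at smaller amounts:
- compound 1, `CC#C[C@@H](Cc1nnn[nH]1)c1ccc(OCc2ccc3sc(C(F)(F)F)c(-c4ccc(OCCOC)cc4C)c3c2)cc1`: 13 nM
- compound 2, `CC#C[C@@H](Cc1nnn[nH]1)c1ccc(OCc2ccc3scc(-c4ccc(OCCC(C)(C)O)cc4C)c3c2)cc1`: 8 nM
- compound 3, `CC#C[C@@H](Cc1nnn[nH]1)c1ccc(OCc2ccc3sc(F)c(-c4ccccc4C)c3c2)cc1`: 15 nM

The three numbers in this assay cannot be told apart: the number for compound 3 differs from that of compound 1 and from that of compound 2 by less than the usual scatter, so nothing can be said about which of the three acts at smaller or larger amounts. Within the data shown here, the three compounds share one core and differ only in what sits on the five-membered ring and in the substituent on the 2-methylphenyl group; with every gap inside the scatter, no step between any two of them is counted.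

Compound 4, `CC#C[C@@H](Cc1nnn[nH]1)c1ccc(OCc2ccc3sc(I)c(-c4ccccc4C)c3c2)cc1`, has not yet been measured. It is derived from compound 3 by a single exchange:
iodo in place of fluoro on an aromatic carbon

Among the measured compounds shown here, no measured step of this kind is available. Given that the varied substituents on the five-membered ring in compound 1, compound 2 and compound 3 leave all values within the scatter of one another, no step beyond the scatter is expected here either; the step of a 1.3-fold lower number from compound 3 to compound 4 (0.10 log units; within the scatter) is the estimate. Compound 4 is expected to give about 12 nM in this assay, with a likely range from 4 nM to 35 nM.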

Compound 4, half-maximal effective concentration: 28 nM
Beside the measured number, compound 4's estimate is 2.3-fold (0.37 log units) below it; measured number inside the range.
By their numbers in this assay, from the lowest: compounds 2, 1, 3 and 4 (each within the scatter of the next, the first and the last beyond it).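

In this assay, among these compounds, iodo in place of fluoro on the aromatic carbon next to the ring sulfur gives a 1.9-fold higher number from compound 3 to compound 4 (0.27 log units; within the scatter) and is the only step here between compounds that differ in one place. With the 2-methylphenyl group unchanged, compound 3 and compound 4 cannot be told apart, so this position carries either halogen without a readable difference, even though the exchange replaces fluorine with iodine. No other data bear on this result.

Compound 1, with trifluoromethyl, and compound 2, with hydrogen at this position, also differ in the substituent on the 2-methylphenyl group, so neither gives a one-place comparison with fluoro or iodo. Going by these compounds, it remains open whether an amine, a nitrile or a carboxylic acid at this position would stay within the scatter of compound 3.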